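The source may hold more compounds than are shown below. What is called first, only, known or untested is meant among the compounds shown, and "the series" means these compounds.

Measured so far:
- compound 1, `Cc1cn(C2CC(O)C(CCC(=O)CI)O2)c(=O)[nH]c1=O` — in a functional assay on HEp-2 cells (Homo sapiens) for inhibition (on this read-out lower numbers stand for stronger inhibition and higher numbers for weaker inhibition), compound 1 gives 17000 nM
- compound 2, `Cc1cn(C2CC(O)C(C(=O)Nc3ccc(C(=O)CBr)cc3)O2)c(=O)[nH]c1=O` — in this assay compound 2 gives 12000 nM
- compound 3, `Cc1cn(C2CC(O)C(CNC(=O)c3ccc(C(=O)CBr)cc3)O2)c(=O)[nH]c1=O` — in this assay compound 3 gives only a limit, > 40000 nM, meaning the assay reports no number for it the limit of > 40000 nM in this assay, at which 1 of the 3 values shown sits.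

Compound 2 has the lowest of the two numbers that are actual numbers, but compound 1 lies close to it, and the gap between the two is within the scatter of this kind of measurement, so no order between compound 2 and compound 1 can be claimed.

Compound 4, `Cc1cn(C2CC(O)C(C(=O)Nc3ccc(C(=O)CCl)cc3)O2)c(=O)[nH]c1=O`, has not yet been measured. It differs from compound 2 in one place: chloro in place of bromo on a saturated chain carbon bound to a carbonyl carbon. The change is small, a single halogen swapped for another on the saturated chain carbon bound to the carbonyl carbon. Among the measured compounds no pair differs by such a swap, so there is no measured step to lean on.

The step from compound 2 to compound 4 in this assay is expected to be modest and, if anything, toward weaker inhibition: a 1.7-fold higher number from compound 2 to compound 4 (0.22 log units; within the scatter). Compound 4 is therefore estimated at 20000 nM, within a range from 8000 nM to 50000 nM, and it is possible that the assay reports only a limit rather than a number.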

Compound 4, half-maximal inhibitory concentration: 30000 nM
Compound 4: the middle estimate sits 1.5-fold (0.18 log units) below what was measured, and the stated range covers the measured number.
By their numbers in this assay, from the lowest: compounds 2, 1 and 4 (each within the scatter of the next, the first and the last beyond it). At a limit, above all of these: compound 3.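

Among the compounds shown here, this is the first measured halogen swap at this place, and it shows that this assay can tell chloro from bromo on a saturated chain carbon bound to a carbonyl carbon: the change gives a 2.5-fold higher number from compound 2 to compound 4 (0.40 log units; beyond the scatter). The step is modest, but only that one atom differs, and no ring, hydrogen-bond donor, hydrogen-bond acceptor or net charge enters or leaves. Compound 3 gives a limit rather than a number, so the read-out stops not far from where compound 4 now stands: the limit of > 40000 nM in this assay, at which 1 of the 4 values shown sits.

From the compounds shown here alone, it remains open whether fluoro at this place, or an amine or a hydroxyl group in place of the halogen, would continue in the same direction. A single pair also cannot show whether the same swap would give a similar step on the core of compound 1 or compound 3.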